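The source may report more compounds than this note shows. Statements on the series, on what has been measured and on what is new or still open speak of the compounds shown alone.

Of the compounds shown here, three that share one core have been measured in a functional assay on HepG2 cells (Homo sapiens) for antiproliferative activity, read by MTT assay, with a stated time of 72 h; a lower number here means a stronger inhibitor, a higher number a weaker inhibitor. Compound 1 `O=C1COc2ccc(-c3cccc(NS(=O)(=O)c4ccc(F)cc4)c3)cc2N1c1ccc(Cl)cc1`, which carries 4-chlorophenyl on an amide-type nitrogen in a ring, gives 27800 nM. Compound 2 `O=C1COc2ccc(-c3cccc(NS(=O)(=O)c4ccc(F)cc4)c3)cc2N1c1ccccc1`, with phenyl at that place, gives 30300 nM, and compound 3 `O=C1COc2ccc(-c3cccc(NS(=O)(=O)c4ccc(F)cc4)c3)cc2N1C1CCCCC1`, with cyclohexyl there, gives 35900 nM. Compound 3 therefore stands level with the other two, since its values lie within the scatter of both.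

Compound 4 `Cc1ccc(N2C(=O)COc3ccc(-c4cccc(NS(=O)(=O)c5ccc(F)cc5)c4)cc32)cc1` has 4-methylphenyl in place of cyclohexyl on an amide-type nitrogen in a ring. The closest guides are the two measured exchanges between an aromatic ring and cyclohexyl at this same nitrogen, a 1.2-fold higher number from compound 2 to compound 3 (0.07 log units; within the scatter) and a 1.3-fold higher number from compound 1 to compound 3 (0.11 log units; within the scatter). Both are small. The step that takes the chloro group off the aromatic ring, a 1.1-fold higher number from compound 1 to compound 2 (0.04 log units; within the scatter), is just as small, although it involves chloro rather than methyl. No measured change at this place has yet gone beyond the scatter, so none is expected here in this assay. The estimated step is a 1.2-fold lower number from compound 3 to compound 4 (0.08 log units; within the scatter), which means no real difference is expected. Compound 4 is expected to give 30000 nM, with an estimated range from 18000 nM to 50000 nM.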

Compound 4, half-maximal inhibitory concentration: > 40000 nM
Compound 4 ended at the assay's limit; the forecaster's own chance of this, stated with the estimate: 10%; middle value at least 1.3-fold (0.12 log units) from the limit.
By their numbers in this assay, from the lowest: compounds 1, 2 and 3 (each within the scatter of the next). At a limit, above all of these: compound 4.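

In this assay compound 4 gives > 40000 nM, which is a limit of the assay and not a number: the limit of > 40000 nM in this assay, at which 1 of the 4 values shown sits.

Every step to compound 4 is therefore only a floor, namely an at least 1.1-fold higher number from compound 3 to compound 4 (0.04 log units; that floor lies within the scatter), an at least 1.3-fold higher number from compound 2 to compound 4 (0.12 log units; that floor lies within the scatter) and an at least 1.4-fold higher number from compound 1 to compound 4 (0.15 log units; that floor lies within the scatter). Compound 1, compound 2 and compound 3 all gave readable values, so the exchanges among them could be sized, whereas 4-methylphenyl on the amide-type nitrogen in a ring gives a result that only bounds the change from one side. Among these compounds, the true value of compound 4 may lie level with the other three or far beyond them, so methyl on the aromatic ring could be as harmless as chloro or hydrogen, or it could be the first real change at this place, and the floors cannot separate these two readings.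

On these data alone, it remains open whether any group on this nitrogen can move the number clearly in either direction, for example a longer chain or a phenyl ring carrying an amine or a carboxylic acid. As far as these compounds go, the shared core also keeps its 4-fluorophenyl group throughout, so how much the rest of the molecule matters in this assay is still unknown.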